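Benzyl for phenyl on the imidazole of compound 3

The source may report more compounds than this note shows. Statements on the series, on what has been measured and on what is new or still open speak of the compounds shown alone.

Compound 3 `C[C@H](c1ccccc1)N1C(=O)O[C@](Cc2ccccc2)(c2ncc(-c3ccccc3)[nH]2)C1=O` gives 4% in an ADME assay (liver) for metabolic stability, with Liver microsome (Rattus norvegicus) as the target, using microsomes, with a stated time of 0.5 h, tested at 1 uM; on this read-out lower numbers stand for a less stable compound and higher numbers for a more stable compound. Among the three measured numbers compound 3 stands second highest; nearest is compound 2 `C[C@H](c1ccccc1)N1C(=O)O[C@](Cc2ccccc2)(c2ncc(Cc3ccccc3)o2)C1=O` at 0%, within the scatter, and furthest is compound 1 `C[C@H](c1ccccc1)N1C(=O)O[C@](Cc2ccccc2)(c2nc(-c3ccccc3)co2)C1=O` at 15%, beyond the scatter, the step of a number 11 percentage points lower from compound 1 to compound 3 (beyond the scatter) belonging to an exchange of the five-membered aromatic ring rather than of the pendant group. Compound 4 `C[C@H](c1ccccc1)N1C(=O)O[C@](Cc2ccccc2)(c2ncc(Cc3ccccc3)[nH]2)C1=O` differs from compound 3 by benzyl in place of phenyl on an aromatic carbon. No measured step covers this change directly; the same exchange on the other five-membered ring is shown by compound 1 giving 15% where compound 2 gives 0%. A small downward step in this assay is therefore expected, bounded by zero. Compound 4 is estimated at 1%, range 0% to 8%, an expected step of a number 3 percentage points lower from compound 3 to compound 4 (within the scatter).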

Compound 4, percent of the compound remaining: 0%
The estimate for compound 4 lay 1 percentage points above the measured number; low and high end bracket the measured number.
By their numbers in this assay, from the lowest: compounds 2, 4 and 3 (each within the scatter of the next); then compound 1.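

In this assay, benzyl in place of phenyl on this aromatic carbon of the five-membered ring with 2 nitrogen gives a number 4 percentage points lower from compound 3 to compound 4 (within the scatter), so this change is not resolved at this position. Both numbers lie so near the bottom of the scale that little room remains to see any further loss. Nothing available bears on the reason for this result.

As far as these compounds go, whether an amine, a carboxylic acid or a longer chain at this carbon would move the number beyond the scatter remains open.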